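Benzofuranyl to ethynyl on the shared core

The compounds below may be only part of what the source reports. "The series", "measured", "known", "first", "only" and "open" are said of these compounds alone.

Measured so far:
compound 1 `COc1nc(N)nc2c1c(-c1cc3ccccc3o1)cn2[C@@H]1O[C@H](CO)[C@@H](O)[C@H]1O` — 25600 nM
compound 2 `COc1ncnc2c1c(-c1cc3ccccc3o1)cn2[C@@H]1O[C@H](CO)[C@@H](O)[C@H]1O` — 22400 nM

In an ADME assay on BJ cells (Homo sapiens), read by MTT assay, with a stated time of 72 h (on this read-out lower numbers stand for stronger inhibition and higher numbers for weaker inhibition), compound 1 gives the highest of the two numbers, with compound 2 nearest: a 1.1-fold lower number from compound 1 to compound 2 (0.06 log units; within the scatter). Compound 3 `C#Cc1cn([C@@H]2O[C@H](CO)[C@@H](O)[C@H]2O)c2nc(N)nc(OC)c12` differs from compound 1 in one place: ethynyl in place of 1-benzofuran-2-yl on an aromatic carbon. Within the data shown here, the only measured step concerns the amino group and does not bear on this exchange, so no measured step supports a direction. For compound 3 the expected value is 40000 nM, with a range of 10000 nM to 120000 nM. The expected step is a 1.6-fold higher number from compound 1 to compound 3 (0.19 log units; within the scatter), given with wide uncertainty.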

Compound 3, half-maximal inhibitory concentration: > 100000 nM
Compound 3: a limit, no number (the forecaster's own chance of this, stated with the estimate: 35%); middle value at least 2.5-fold (0.39 log units) away from the limit.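

In this assay, the aromatic carbon of the shared core that bears 1-benzofuran-2-yl is sensitive to exchange: ethynyl gives an at least 3.9-fold higher number from compound 1 to compound 3 (0.59 log units; beyond the scatter), whereas the earlier step, at the amino group, stayed within the scatter. The reading for compound 3 is a limit, not a number: the limit of > 100000 nM in this assay, at which 1 of the 3 values shown sits.

From the compounds shown here alone, the full size of this step therefore stays open. Also open, going by these compounds, is whether a phenyl or propyl group on this carbon would give a number close to that of compound 1, or a limit like that of compound 3.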